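The compounds below may be only part of what the source reports. "The series", "measured", "known", "first", "only" and "open" are said of these compounds alone.

Measured so far in an ADME assay on the whole organism (Rattus norvegicus, strain Fischer 344) for pharmacokinetics, at a dose of 3 mg/kg by the oral route; on this read-out lower numbers stand for lower exposure and higher numbers for higher exposure at the dose given:
- compound 1 `NC(=O)c1sc2nccc(N3CCC[C@H](COCC(=O)N4CCOCC4)C3)c2c1N`: 501 nM
- compound 2 `COC[C@H]1CCCN(c2ccnc3sc(C(N)=O)c(N)c23)C1`: 251 nM

Within the data shown here, with only two numbers available, compound 2 at 251 nM cannot be separated from compound 1, since the two lie within the usual scatter of each other. The next structure is compound 3 `NC(=O)c1sc2nccc(N3CCC[C@H](COCCO)C3)c2c1N`. It keeps the core of compound 2 and differs in one place: hydroxymethyl in place of hydrogen on a saturated chain carbon bound to an oxygen on a saturated carbon. In words, hydroxymethyl stands in place of hydrogen on a saturated chain carbon bound to an oxygen on a saturated carbon, which turns methoxy into 2-hydroxyethoxy.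

Among the measured compounds shown here, one measured step bears on this place: a 2.0-fold lower number from compound 1 to compound 2 (0.30 log units; within the scatter). There, hydrogen replaced a whole (morpholin-4-yl)carbonyl, and the size of that step gives no sign of a real change in this assay. For the measured compounds named here, no measured compound carries the new hydroxyl end, so this is indirect evidence. No step beyond the scatter is therefore expected, and the estimated change is a 1.2-fold higher number from compound 2 to compound 3 (0.08 log units; within the scatter). Compound 3 is expected at 300 nM, with an estimated range from 120 nM to 750 nM.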

Compound 3, maximal plasma concentration: 326 nM
For compound 3 the middle estimate is 1.1-fold (0.04 log units) below the measured one; the range from low to high includes it.
By their numbers in this assay, from the lowest: compounds 2, 3 and 1 (each within the scatter of the next).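

In this assay the new hydroxyl end gives a 1.3-fold higher number from compound 2 to compound 3 (0.11 log units; within the scatter) and so methoxy and 2-hydroxyethoxy cannot be told apart at this position. Putting hydroxymethyl where the (morpholin-4-yl)carbonyl stood, on the same saturated chain carbon bound to an oxygen on a saturated carbon, gives a 1.5-fold lower number from compound 1 to compound 3 (0.19 log units; within the scatter) and so this pair cannot be separated either; hydrogen, hydroxymethyl and (morpholin-4-yl)carbonyl at this place now form a set of three with no step beyond the scatter among them, whether the group that enters is small or carries a whole ring. No measurement shown here offers an explanation for this flat picture.

From the compounds shown here alone, what remains open is whether any group at this chain end can produce a step beyond the scatter, for example an amine or a carboxylic acid in place of the hydroxyl of compound 3. It is also open how a longer chain with the same hydroxyl end would read, since the compounds shown stop at 2-hydroxyethoxy among the simple chains.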